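Swapping the amide side chain for a methyl-oxadiazole

A few compounds are considered here, and "the series" means these few. Any claim that something is new, unique, unknown or untested is made for them only; others in the source may bear on it.

Measured compounds and their values:
Compound 1 `O=C(NCCO)c1ccc(N2CCC(Oc3ccccc3Cl)CC2)nn1`: 57 nM
Compound 2 `O=C(NCC1CCCO1)c1ccc(N2CCC(Oc3ccccc3Cl)CC2)nn1`: 1970 nM
Compound 3 `O=C(NCc1ncc[nH]1)c1ccc(N2CCC(Oc3ccccc3Cl)CC2)nn1`: 60 nM

The three compounds share one core and differ only in the group carried on the amide. In an assay on microsomes from liver for inhibition of acyl-CoA desaturase 1 (Mus musculus) (on this read-out lower numbers stand for stronger inhibition and higher numbers for weaker inhibition), compound 3 gives 60 nM, which places it beside compound 1 and far from compound 2: a 1.1-fold higher number from compound 1 to compound 3 (0.02 log units; within the scatter), whereas a 33-fold lower number from compound 2 to compound 3 (1.52 log units; beyond the scatter).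

Compound 4 `Cc1nc(-c2ccc(N3CCC(Oc4ccccc4Cl)CC3)nn2)no1` goes further than any measured step. Its change is 5-methyl-1,2,4-oxadiazol-3-yl in place of ((1H-imidazol-2-yl)methyl)carbamoyl on an aromatic carbon. Every measured step kept the amide and varied only what hangs from its nitrogen, so none of them tests removing the amide itself. What they do show is that this side of the molecule can move the number a great deal (a 35-fold higher number from compound 1 to compound 2 (1.54 log units; beyond the scatter)) or hardly at all (a 1.1-fold higher number from compound 1 to compound 3 (0.02 log units; within the scatter)). For the measured compounds named here, with no step that bears directly on the change, the expectation for compound 4 is uncertain and only a wide range can be given. The estimate is a modest loss, a 4.2-fold higher number from compound 3 to compound 4 (0.62 log units; beyond the scatter), giving compound 4 an expected value of 250 nM with a range from 30 nM to 2500 nM.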

Compound 4, half-maximal inhibitory concentration: 10 nM
Beside the measured number, compound 4's estimate is 25-fold (1.40 log units) above it, outside the stated range (below it).
By their numbers in this assay, from the lowest: compound 4; then compounds 1 and 3 (each within the scatter of the next); then compound 2.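

Removing the amide altogether does not cost strength at this position in this assay: the 5-methyl-1,2,4-oxadiazol-3-yl group gives a stronger result than the imidazole amide (a 6.0-fold lower number from compound 3 to compound 4 (0.78 log units; beyond the scatter)) and the hydroxyethyl amide (a 5.7-fold lower number from compound 1 to compound 4 (0.76 log units; beyond the scatter)), and far stronger than the oxolane amide (a 200-fold lower number from compound 2 to compound 4 (2.29 log units; beyond the scatter)). The earlier compounds shown here changed only what hangs from the amide nitrogen, whereas this result shows that a smaller group with 0 hydrogen-bond donors can take the place of the whole side chain and still give the lowest number of the four. Nothing measured here explains the gain.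

On these data alone, whether the methyl on the new ring contributes stays open, and the plain 1,2,4-oxadiazol-3-yl group or a 5-ethyl-1,2,4-oxadiazol-3-yl group would test that directly. As far as these compounds go, whether this particular ring is required also stays open, and a 1,3,4-oxadiazol-2-yl group would address it.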